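Removing the allyl group from compound 2

The source may report more compounds than this note shows. Statements on the series, on what has been measured and on what is new or still open speak of the compounds shown alone.

Compound 1 `COc1cc(OC)c(C(=O)/C=C/c2ccccc2)c(OC)c1`: 5200 nM
Compound 2 `C=CCOc1ccccc1Cc1c(OC)cc(OC)c(C(=O)/C=C/c2ccccc2)c1OC`: 5800 nM

In a functional assay on HeLa cells (Homo sapiens) for cytotoxicity, read by resazurin assay, with a stated time of 72 h (a lower number here means a stronger inhibitor, a higher number a weaker inhibitor), compound 2 gives 5800 nM, which lies within the scatter of compound 1. Compound 3 `COc1cc(OC)c(C(=O)/C=C/c2ccccc2)c(OC)c1Cc1ccccc1O` differs from compound 2 as follows: hydrogen in place of allyl on an oxygen on an aromatic ring. This is hydrogen in place of allyl on an oxygen on an aromatic ring, which turns 2-(allyloxy)benzyl into 2-hydroxybenzyl. Among the compounds with values here, the only measured step, a 1.1-fold higher number from compound 1 to compound 2 (0.05 log units; within the scatter), introduced the whole 2-(allyloxy)benzyl group. Within the data shown here, no measured step isolates the allyl group, so no change beyond the scatter is expected. The expected step is a 1.3-fold lower number from compound 2 to compound 3 (0.11 log units; within the scatter). For compound 3 the estimate is 4500 nM, with a range from 1800 nM to 11000 nM.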

Compound 3, half-maximal inhibitory concentration: 2700 nM
Beside the measured number, compound 3's estimate is 1.7-fold (0.22 log units) above it; measured number inside the range.
By their numbers in this assay, from the lowest: compounds 3, 1 and 2 (each within the scatter of the next, the first and the last beyond it).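

Within the data shown here, replacing the allyl with hydrogen on the oxygen gives the only step at this position that lies beyond the scatter in this assay, a modest one: a 2.1-fold lower number from compound 2 to compound 3 (0.33 log units; beyond the scatter). Against the unsubstituted core, however, the 2-hydroxybenzyl group gives a 1.9-fold lower number from compound 1 to compound 3 (0.28 log units; within the scatter), which stays within the scatter, so hydroxy and allyloxy can be told apart here, but neither can be told apart from hydrogen on the aromatic carbon. Nothing available explains the difference between hydroxy and allyloxy. The compounds shown leave open how a plain benzyl group, or an amine in place of the hydroxy, would read.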